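Urea aryl swap on the ethylamine-linked thienopyrimidine series

This account rests on a few compounds, and the source may have more. Where it says the series, first, only, none or still open, it means among the compounds named here.

Two compounds of this series have numbers in a functional assay on HT-29 cells (Homo sapiens) for cytotoxicity, read by MTT assay, with a stated time of 72 h (on this read-out lower numbers stand for stronger inhibition and higher numbers for weaker inhibition), so far. Compound 1 `CN(C)CCCNc1nc(-c2ccc(NC(=O)Nc3ccc(Cl)cc3Cl)cc2)nc2ccsc12` gives 1860 nM in this assay. For the measured compounds named here, compound 2 `CN(C)CCNc1nc(-c2ccc(NC(=O)Nc3ccccc3F)cc2)nc2ccsc12` gives 510 nM in this assay, the lowest of the two numbers, with compound 1 the only neighbour, at a higher number that lies beyond the scatter. Going by the values given here, compound 1 and compound 2 differ in more than one place, so no single step between them is on hand.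

Compound 3 `CN(C)CCNc1nc(-c2ccc(NC(=O)Nc3ccc(Cl)cc3Cl)cc2)nc2ccsc12` is not yet measured in this assay. It departs from compound 2 by one change, (2,4-dichlorophenyl in place of 2-fluorophenyl on an amide-type nitrogen). Compound 1 carries the same 2,4-dichlorophenyl group, yet it also differs from compound 2 elsewhere, so its number cannot be read as the effect of the aryl swap alone. Among the compounds with values here, with no measured step to lean on, the expectation for the step from compound 2 to compound 3 is a modest rise, a 1.8-fold higher number from compound 2 to compound 3 (0.25 log units; within the scatter), with a wide spread around it. Compound 3 is therefore estimated at 900 nM in this assay, within a range from 300 nM to 3000 nM.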

Compound 3, half-maximal inhibitory concentration: 1320 nM
Compound 3: middle estimate off by 1.5-fold (0.17 log units), on the low side; the measured number falls inside the stated range.
By their numbers in this assay, from the lowest: compound 2; then compounds 3 and 1 (each within the scatter of the next).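

In this assay, the position on the amide-type nitrogen responds to this aryl swap: 2,4-dichlorophenyl in place of 2-fluorophenyl gives a 2.6-fold higher number from compound 2 to compound 3 (0.41 log units; beyond the scatter), and compound 2 keeps the lowest number of the set. For the compounds shown here, the first single step on the chain, with 2,4-dichlorophenyl held constant, gives a 1.4-fold lower number from compound 1 to compound 3 (0.15 log units; within the scatter), so compound 1 and compound 3 are not told apart and, among the steps read so far, only the aryl swap moves the number beyond the scatter. Nothing at hand bears on why the aryl swap has this size.

The compounds shown do not separate the loss of 2-fluorophenyl from the entry of the two chlorines, and a plain phenyl, 2-chlorophenyl or 4-chlorophenyl on the same nitrogen would divide that step into its parts. Going by these compounds, it also remains open whether the chain step stays this small with 2-fluorophenyl in place, and how a morpholine or piperidine in place of the dimethylamino group would read in this assay.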